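Acetyl to methylcarbamoyl on the shared core

The source may hold more compounds than are shown below. What is called first, only, known or untested is meant among the compounds shown, and "the series" means these compounds.

In an assay on HEK-293T cells for inhibition of diacylglycerol lipase-alpha (Homo sapiens), read by colorimetric assay (on this read-out higher numbers stand for weaker inhibition and lower numbers for stronger inhibition), compound 2 `CC(=O)c1coc(C(=O)CCCCCCc2ccccc2)n1` stands at 123 nM. Compound 1 `O=C(CCCCCc1ccccc1)c1nc2cnccc2o1` stands at 204 nM in this assay, and the gap between the two lies within the scatter, so neither is set apart. Compound 3 `CNC(=O)c1coc(C(=O)CCCCCCc2ccccc2)n1` is not yet measured; it differs from compound 2 by methylamino in place of methyl on a carbonyl carbon, on a carbonyl carbon whose other neighbour is an aromatic carbon. For the measured compounds named here, no measured pair covers this change, so the data give no direction for it. The step of a 1.2-fold higher number from compound 2 to compound 3 (0.09 log units; within the scatter) is expected to stay within the scatter. Compound 3 is estimated at 150 nM in this assay, with a range of 50 nM to 500 nM.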

Compound 3, half-maximal inhibitory concentration: > 10000 nM
Compound 3: a limit, no number; the forecaster's own chance of this, stated with the estimate: 5%; at least 66-fold (1.82 log units) between middle value and limit.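

On a carbonyl carbon whose other neighbour is an aromatic carbon, methylamino in place of methyl gives an at least 81-fold higher number from compound 2 to compound 3 (1.91 log units; beyond the scatter). In this assay compound 3 gives > 10000 nM, which is a limit of the assay and not a number. For the compounds shown here, this position, for which the earlier compounds gave no direction, therefore responds strongly to this single change, and the full size of the step stays unknown.

Still open, from the compounds shown here alone, is how an ethyl, a methoxy or a dimethylamino group on this carbonyl carbon would read, so the step cannot yet be tied to the nitrogen or to the amide hydrogen.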